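Swapping Chloro for Bromo on a Weak Antiproliferative Core

This account rests on a few compounds, and the source may have more. Where it says the series, first, only, none or still open, it means among the compounds named here.

Two compounds share one core. Compound 1 `NC(=O)c1c(NC(=O)c2ccccc2Cl)sc2c1CCN(C(=S)Nc1cccc3ccccc13)C2` carries naphthalen-1-yl on an amide-type nitrogen, and in a functional assay on HeLa cells (Homo sapiens) for antiproliferative activity, with a stated time of 24 h (a higher number here means a weaker inhibitor, a lower number a stronger inhibitor), compound 1 gives 30800 nM. Compound 2 `NC(=O)c1c(NC(=O)c2ccccc2Cl)sc2c1CCN(C(=S)Nc1ccccc1F)C2` carries 2-fluorophenyl there, and in this assay compound 2 gives 28700 nM. Of the two numbers, compound 2 holds the smaller one, yet the step of a 1.1-fold lower number from compound 1 to compound 2 (0.03 log units; within the scatter) lies within the scatter, so the two compounds are effectively alike.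

Compound 3 `NC(=O)c1c(NC(=O)c2ccccc2Br)sc2c1CCN(C(=S)Nc1ccccc1F)C2` differs from compound 2 in one place: bromo in place of chloro on an aromatic carbon. Within the data shown here, no measured step touches this part of the molecule; the only step known, a 1.1-fold lower number from compound 1 to compound 2 (0.03 log units; within the scatter), concerns the group on the amide-type nitrogen and shows that even a large exchange there left this assay nearly unchanged. A halogen-for-halogen swap on the (2-chlorophenyl)carbonyl part is therefore expected to move the number little, if at all beyond the scatter. Compound 3 is estimated at 27000 nM, within 13000 nM to 55000 nM, an expected step of a 1.1-fold lower number from compound 2 to compound 3 (0.03 log units; within the scatter).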

Compound 3, half-maximal inhibitory concentration: > 50000 nM
Compound 3 ended at the assay's limit; the forecaster's own chance of this, stated with the estimate: 5%; middle value at least 1.8-fold (0.26 log units) from the limit.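

In this assay, the reading for compound 3 is a limit of the assay and not a number: the limit of > 50000 nM in this assay, at which 1 of the 3 values shown sits. Compounds 1 and 2 differ only in the group on the amide-type nitrogen, whereas this pair tests the halogen on the aromatic carbon, and the step is an at least 1.7-fold higher number from compound 2 to compound 3 (0.24 log units; that floor lies within the scatter). Only a floor is known, so bromo in place of chloro may have weakened the compound substantially or may have changed it by no more than the scatter, but it brought no gain in strength in this assay.

The compounds shown carry only chloro or bromo at this position, so it remains open whether a halogen is needed there at all. A methoxy group, an amine or a plain hydrogen in that place would help to answer this.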